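A few compounds are considered here, and "the series" means these few. Any claim that something is new, unique, unknown or untested is made for them only; others in the source may bear on it.

Measured compounds, all in a functional assay on A549 cells (Homo sapiens) for antiproliferative activity, read by MTT assay, with a stated time of 72 h; a lower number here means a stronger inhibitor, a higher number a weaker inhibitor:
compound 1 `Cn1ccc2c(Oc3ccc(NC(=O)c4cc5cccnc5n(-c5ccc(Cl)cc5)c4=O)cc3)ccnc21`, 630 nM
compound 2 `Cn1ccc2c(Oc3ccc(NC(=O)c4cc5cccnc5n(-c5ccc(F)cc5)c4=O)cc3F)ccnc21`, 280 nM
compound 3 `Cn1ccc2c(Oc3ccc(NC(=O)c4cc5cccnc5n(-c5ccc(Cl)cc5)c4=O)cc3F)ccnc21`, 350 nM

Compound 3 sits second highest of the three numbers; its nearest neighbour is compound 2 and its furthest is compound 1, and both gaps lie within the scatter, so no order among the three can be read from them. The two steps that reach compound 3 are a 1.8-fold lower number from compound 1 to compound 3 (0.26 log units; within the scatter) and a 1.3-fold higher number from compound 2 to compound 3 (0.10 log units; within the scatter); neither rises beyond the scatter.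

Compound 4 `Cn1ccc2c(Oc3ccc(NC(=O)c4cc5cccnc5n(-c5ccc(C(F)(F)F)cc5Cl)c4=O)cc3F)ccnc21` differs from compound 3 by 2-chloro-4-(trifluoromethyl)phenyl in place of 4-chlorophenyl on an aromatic nitrogen. Within the data shown here, no measured step exchanges this ring for one carrying two groups; the only change on it among the measured compounds is chloro in place of fluoro, which stayed within the scatter. With that single precedent, the step expected for compound 4 is a 1.1-fold higher number from compound 3 to compound 4 (0.06 log units; within the scatter), that is, no movement beyond the scatter; the change is larger than any measured one, so the range is kept wide. Compound 4 is therefore estimated at 400 nM in this assay, within 150 nM to 1100 nM.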

Compound 4, half-maximal inhibitory concentration: 3530 nM
For compound 4 the middle estimate is 8.8-fold (0.95 log units) below the measured one; measured number outside the range, above it.
By their numbers in this assay, from the lowest: compounds 2, 3 and 1 (each within the scatter of the next, the first and the last beyond it); then compound 4.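

Among these compounds, on the aryl group carried by the aromatic nitrogen, the only earlier change, chloro in place of fluoro, stayed within the scatter in this assay. Among the compounds shown here, the larger group 2-chloro-4-(trifluoromethyl)phenyl brings the first change at this position that goes beyond the scatter: a 10-fold higher number from compound 3 to compound 4 (1.00 log units; beyond the scatter), and a 13-fold higher number from compound 2 to compound 4 (1.10 log units; beyond the scatter), so this position is not indifferent to every exchange. No measurement available here bears on the origin of this rise.

The entering group adds a chloro and a trifluoromethyl group together, so the compounds shown do not divide the step between the two. From the compounds shown here alone, how a ring bearing a methoxy group or an amine at this position would read in this assay also remains open.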